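The compounds below may be only part of what the source reports. "The series", "measured", "known", "first", "only" and "open" are said of these compounds alone.

For the measured compounds named here, in an ADME assay on RAW264.7 cells (Mus musculus) for cytotoxicity, read by MTT assay, with a stated time of 72 h, tested at 50 uM (on this read-out higher numbers stand for more inhibition at the one concentration tested (going by the name of the read-out) and lower numbers for less inhibition), compound 2 `CCOC(=O)c1sc(-c2ccccc2)nc1N1CCC(NCc2ccc(Cl)c(Cl)c2)CC1` gives 18.1%, and the only other number in hand belongs to compound 1 `CCOC(=O)c1sc(-c2ccccc2)nc1N1CCC(NCc2ccc(C(F)(F)F)cc2)CC1`, which gives 22.7% in this assay; the step of a number 4.6 percentage points lower from compound 1 to compound 2 (within the scatter) lies within the scatter, so the two compounds cannot be told apart. Compound 3 `CCOC(=O)c1sc(-c2ccccc2)nc1N1CCC(NCc2ccc(Cl)cc2Cl)CC1` differs from compound 2 by 2,4-dichlorophenyl in place of 3,4-dichlorophenyl on a saturated chain carbon bound to an amine nitrogen. Going by the values given here, the one measured step that bears on this change, from compound 1 to compound 2, was within the scatter, so no step beyond the scatter is expected here. Compound 3 is therefore estimated at 20%, in the range 8% to 32%, an expected step of a number 1.9 percentage points higher from compound 2 to compound 3 (within the scatter).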

Compound 3, a percentage reported as inhibition, at one concentration (the size of the read-out at that concentration, not a potency): 9.43%
Estimate against measurement, compound 3: 10.6 percentage points above, and the stated range covers the measured number.
By their numbers in this assay, from the lowest: compounds 3, 2 and 1 (each within the scatter of the next, the first and the last beyond it).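

In this assay, 2,4-dichlorophenyl in place of 3,4-dichlorophenyl gives a number 8.7 percentage points lower from compound 2 to compound 3 (within the scatter), so these two dichlorophenyl groups cannot be told apart at this place. Against 4-(trifluoromethyl)phenyl, however, 2,4-dichlorophenyl gives a number 13.3 percentage points lower from compound 1 to compound 3 (beyond the scatter), the only step at this position beyond the scatter, and a modest one. Nothing at hand accounts for this step. From the compounds shown here alone, it remains open how an unsubstituted phenyl, a 4-methoxyphenyl or a pyridyl group on the same saturated chain carbon would read in this assay.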